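Series notes: from compound 1 to compound 3

A few compounds are considered here, and "the series" means these few. Any claim that something is new, unique, unknown or untested is made for them only; others in the source may bear on it.

In an ADME assay on LLC-PK11 cells (Sus scrofa) for cytotoxicity, read by neutral red uptake, with a stated time of 48 h (on this read-out lower numbers stand for stronger inhibition and higher numbers for weaker inhibition), compound 1 (`O=c1sc2ccccc2n1CCCN1CCN(CCCn2c(=O)sc3ccccc32)CC1`) gives 23500 nM as its half-maximal inhibitory concentration, and compound 2 (`O=c1sc2ccccc2n1CCCN1CCN(CCn2c(=O)sc3ccccc32)CC1`) gives 24100 nM on the same read-out. These two numbers lie within the scatter of each other, so compound 1 shares a single band with compound 2 and has no separate standing.

Compound 3 (`O=c1sc2ccccc2n1CCCCN1CCN(CCCn2c(=O)sc3ccccc32)CC1`) is still to be measured. Relative to compound 1 the change is as follows (a group of 11 heavy atoms (8 carbon, 1 nitrogen, 1 oxygen, 1 sulfur; one five-membered aromatic ring with 2 hetero atoms, one six-membered aromatic ring of carbon only) in place of a group of 10 heavy atoms (7 carbon, 1 nitrogen, 1 oxygen, 1 sulfur; one five-membered aromatic ring with 2 hetero atoms, one six-membered aromatic ring of carbon only), on a saturated chain carbon, three bonds along the chain from an amine nitrogen in a ring), on a saturated chain carbon, three bonds along the chain from an amine nitrogen in a ring. The entering group has the same rings and the same hydrogen-bond acceptors as the leaving group.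

Among the compounds with values here, no measured step between compounds differing in one place is available, so the expectation has only a thin basis. Within the data shown here, the one guide is the shared band of compound 1 at 23500 nM and compound 2 at 24100 nM in this assay, and no direction is favoured. The estimated step is a 1.1-fold lower number from compound 1 to compound 3 (0.03 log units; within the scatter) and is expected to stay within the scatter.

For compound 3 the expected value is 22000 nM with a range from 11000 nM to 44000 nM as estimated.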

Compound 3, half-maximal inhibitory concentration: 19200 nM
Estimate against measurement, compound 3: 1.1-fold (0.06 log units) above, and the stated range covers the measured number.
By their numbers in this assay, from the lowest: compounds 3, 1 and 2 (each within the scatter of the next).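

In this assay, within the data shown here, the only step available between compounds differing in one place is a 1.2-fold lower number from compound 1 to compound 3 (0.09 log units; within the scatter), with the group of 11 heavy atoms in place of the group of 10 heavy atoms, on a saturated chain carbon, three bonds along the chain from an amine nitrogen in a ring. The earlier compounds shown here gave only a shared band, whereas this step tests a single change at this position: with the rings and hydrogen-bond acceptors the same in both groups, this change does not separate compound 3 from compound 1 on this read-out. No measurement at hand offers a reason for this result.

As far as these compounds go, one step at one position gives no trend, so the outcome in this assay for a longer chain at this place remains open. Also open is whether an amine or a carboxylic acid on that saturated chain carbon would give a step beyond the scatter, and the compounds shown say nothing about any other read-out.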